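The source may report more compounds than this note shows. Statements on the series, on what has been measured and on what is new or still open speak of the compounds shown alone.

Working notes on the series. In a functional assay on Jurkat cells (Homo sapiens) for antiproliferative activity, read by MTT assay, with a stated time of 72 h (a lower number here means a stronger inhibitor of growth, a higher number a weaker inhibitor of growth), compound 1 `Cc1ccc(Cl)cc1-n1nnc(C(=O)Nc2ccc(SC#N)cc2)c1C` gives 680 nM and compound 2 `Cc1ccc(Cl)c(-n2nnc(C(=O)Nc3ccc(SC#N)cc3)c2C)c1` gives 66300 nM as the higher of the two numbers, so compound 2 is the weaker growth inhibitor of this pair. The next compound is compound 3 `COc1cccc(-n2nnc(C(=O)Nc3ccc(SC#N)cc3)c2C)c1`, with 3-methoxyphenyl in place of 2-chloro-5-methylphenyl on an aromatic nitrogen, counted as 3-methoxyphenyl in place of 2-chloro-5-methylphenyl on an aromatic nitrogen in full. Within the data shown here, the one measured step at this place is a 98-fold higher number from compound 1 to compound 2 (1.99 log units; beyond the scatter) and it is large, so this group can move the number a long way. Among the measured compounds shown here, no measured compound carries a methoxy group, which leaves the evidence thin. A moderate to large drop in this assay is expected, with the estimated step being an 11-fold lower number from compound 2 to compound 3 (1.04 log units; beyond the scatter) under wide uncertainty. By this estimate compound 3 is expected at 6000 nM within 800 nM to 45000 nM as its range.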

Compound 3, concentration for 50% growth inhibition: > 100000 nM
Compound 3: no number, only a limit (the forecaster's own chance of this, stated with the estimate: 8%); at least 16-fold (1.22 log units) between middle value and limit.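

In this assay compound 3 gives a limit and not a number: the limit of > 100000 nM in this assay, at which 1 of the 3 values shown sits. From the compounds shown here alone, the step is an at least 1.5-fold higher number from compound 2 to compound 3 (0.17 log units; that floor lies within the scatter), so this reading alone does not separate the two compounds, and how far 3-methoxyphenyl lies from 2-chloro-5-methylphenyl stays unknown. Among these compounds, the other step, an at least 140-fold higher number from compound 1 to compound 3 (2.16 log units; beyond the scatter), shows that a second group at this aromatic nitrogen, one with oxygen and no chlorine, also falls far short of 5-chloro-2-methylphenyl, so the large loss is no longer tied to the one swap seen earlier.

Among the three compounds, only 5-chloro-2-methylphenyl gives a reading in the high-potency range, and which of its two substituents carries that reading stays open. Also open, going by these compounds, is how a plain phenyl ring, or a phenyl ring bearing an amine or a carboxylic acid, would behave at this nitrogen.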